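Replacing Chloro with Dimethylamino in Compound 3

The source may hold more compounds than are shown below. What is called first, only, known or untested is meant among the compounds shown, and "the series" means these compounds.

Compound 1 `O=C1/C(=C\c2ccc(O)cc2)S/C(=N/c2ccccc2)N1Cc1ccncc1`: 18900 nM
Compound 2 `COc1ccc(/C=C2/S/C(=N/c3ccccc3)N(Cc3ccncc3)C2=O)cc1`: 31500 nM
Compound 3 `O=C1/C(=C\c2ccc(Cl)cc2)S/C(=N/c2ccccc2)N1Cc1ccncc1`: 54900 nM

These values all come from one test. In a functional assay on MCF7 cells (Homo sapiens) for cytotoxicity, read by MTT assay, with a stated time of 48 h (a higher number here means a weaker inhibitor, a lower number a stronger inhibitor), compound 3 gives 54900 nM. Against the other two, the comparison shows a 2.9-fold higher number from compound 1 to compound 3 (0.46 log units; beyond the scatter) and a 1.7-fold higher number from compound 2 to compound 3 (0.24 log units; within the scatter). Compound 3 therefore cannot be told apart from one neighbour but stands clearly apart from the other.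

Compound 4 `CN(C)c1ccc(/C=C2/S/C(=N/c3ccccc3)N(Cc3ccncc3)C2=O)cc1` keeps the core of compound 3 but has dimethylamino in place of chloro on an aromatic carbon, para to a large group: dimethylamino in place of chloro on an aromatic carbon. Within the data shown here, no measured compound carries dimethylamino, so the expectation rests on the changes already seen at this same spot. Those changes were small, and the third comparison shows a 1.7-fold higher number from compound 1 to compound 2 (0.22 log units; within the scatter). The new group is expected to land in or near this narrow band of numbers. The estimate means a 1.7-fold lower number from compound 3 to compound 4 (0.23 log units; within the scatter), an expected move no larger than those measured. Compound 4 is expected at 32000 nM, with an estimated range of 12000 nM to 75000 nM.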

Compound 4, half-maximal inhibitory concentration: 76300 nM
Estimate against measurement, compound 4: 2.4-fold (0.38 log units) below; measured number above the stated range.
By their numbers in this assay, from the lowest: compounds 1, 2, 3 and 4 (each within the scatter of the next, the first and the last beyond it).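

In this assay, swapping chloro for dimethylamino gives a 1.4-fold higher number from compound 3 to compound 4 (0.14 log units; within the scatter) and so leaves these two groups indistinguishable at this position. Dimethylamino does stand apart from the other two groups, with a 2.4-fold higher number from compound 2 to compound 4 (0.38 log units; beyond the scatter) and a 4.0-fold higher number from compound 1 to compound 4 (0.61 log units; beyond the scatter), and that last step is the widest gap yet seen at this spot, wider than any step among the first three compounds. Nothing measured here explains why these groups differ.

Among these compounds, the four compounds vary only this one group, so it remains open how a carboxylic acid, a primary amine or a longer alkoxy chain would read at the same spot. Going by these compounds, whether the same order of groups would hold with other parts of the shared core changed also remains open.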